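The source may report more compounds than this note shows. Statements on the series, on what has been measured and on what is new or still open speak of the compounds shown alone.

Among the measured compounds shown here, compound 2, with the structure `Cc1nnc(SCC(=O)Nc2ccc(-c3nc(-c4ccccc4)c(-c4ccccc4)n3C)cc2)s1`, stands highest of the two numbers measured so far: in a functional assay on MCF7 cells (Homo sapiens) for cytotoxicity, read by MTT assay, with a stated time of 24 h, tested at 0.64 ug/mL (a lower number here means a weaker effect, a higher number a stronger effect of the compound at the concentration tested), compound 2 gives 35.1%. For the measured compounds named here, its only neighbour is compound 1, with the structure `Cc1ccc2oc(SCC(=O)Nc3ccc(-c4nc(-c5ccccc5)c(-c5ccccc5)n4C)cc3)nc2c1`, which in this assay gives 1.1%. Going by the values given here, the one measured step is a number 34 percentage points higher from compound 1 to compound 2 (beyond the scatter), brought about by putting 5-methyl-1,3,4-thiadiazol-2-yl in place of 5-methyl-1,3-benzoxazol-2-yl on a sulfur.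

Compound 3, with the structure `Cn1ccnc1SCC(=O)Nc1ccc(-c2nc(-c3ccccc3)c(-c3ccccc3)n2C)cc1`, has not yet been measured. It differs from compound 2 in one place: 1-methyl-1H-imidazol-2-yl in place of 5-methyl-1,3,4-thiadiazol-2-yl on a sulfur. The measured step bears on this change only loosely, as it exchanged a different group on the sulfur whose other neighbour is a saturated chain carbon; it does show that an exchange at this place can move the read-out by a large amount, and that the 5-methyl-1,3,4-thiadiazol-2-yl group, which now leaves, sat on the stronger side of that step. The direction for compound 3 is therefore uncertain, and I expect a step of a number 15.1 percentage points lower from compound 2 to compound 3 (beyond the scatter), downward. For compound 3 I estimate 20% in this assay, expected within 2% to 45%.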

Compound 3, a percentage reported as activity, at one concentration (the size of the read-out at that concentration, not a potency): 10.3%
Compound 3: the middle estimate sits 9.7 percentage points above what was measured, within the range that was stated.
By their numbers in this assay, from the lowest: compounds 1 and 3 (each within the scatter of the next); then compound 2.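

In this assay, the exchange on a sulfur whose other neighbour is a saturated chain carbon gives a number 24.8 percentage points lower from compound 2 to compound 3 (beyond the scatter), so even two single five-membered aromatic rings with the same number of heavy atoms are not interchangeable here. The other new step reads a number 9.2 percentage points higher from compound 1 to compound 3 (within the scatter), which leaves compound 1 and compound 3 not distinguishable in this read-out and makes compound 2 the only one of the three that stands clearly apart, with steps beyond the scatter to both others. Nothing available explains why 5-methyl-1,3,4-thiadiazol-2-yl stands apart from the other two groups.

The step from compound 2 to compound 3 alters the ring's hetero atoms and its methyl group together, so these compounds cannot show which of those alterations matters. Also open, on these data alone, is how the read-out would respond to a group on the sulfur that is not an aromatic ring, such as an ethyl chain or a short chain ending in a carboxylic acid, and a single tested concentration gives no potency for any of them.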